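Trifluoromethoxy for Trifluoromethyl on the Sulfonyl Aryl

The compounds below may be only part of what the source reports. "The series", "measured", "known", "first", "only" and "open" are said of these compounds alone.

Compound 3 `O=C(COc1ccc2c(=O)ccoc2c1)Nc1cccc(NS(=O)(=O)c2ccc(C(F)(F)F)cc2)c1` carries a 4-(trifluoromethyl)phenyl on the sulfonyl sulfur of the shared core. In an assay on isolated protein for inhibition of Rho-associated protein kinase 1 (Homo sapiens), read by scintillation counting, radiometric assay and 33P incorporation, with a stated time of 40 min, in the presence of a further agent that is not named here (a higher number here means a weaker inhibitor, a lower number a stronger inhibitor), compound 3 gives > 10000 nM, which is a limit of the assay and not a number. Compound 1 `Cn1ccc(S(=O)(=O)Nc2cccc(NC(=O)COc3ccc4c(=O)ccoc4c3)c2)n1`, with 1-methyl-1H-pyrazol-3-yl in that place, gives in this assay > 10000 nM, also a limit. Within the data shown here, compound 2 `CN(C)c1ccc(S(=O)(=O)Nc2cccc(NC(=O)COc3ccc4c(=O)ccoc4c3)c2)cc1`, with 4-(dimethylamino)phenyl, gives in this assay 803 nM, the only numerical value among the three; the set shows (the limit of > 10000 nM in this assay, at which 2 of the 3 values shown sit). The step of an at least 12-fold lower number from compound 1 to compound 2 (1.09 log units; beyond the scatter) is large, and an at least 12-fold higher number from compound 2 to compound 3 (1.09 log units; beyond the scatter) is as large in the opposite direction, while a step that the two limits leave unreadable from compound 1 to compound 3.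

Compound 4 `O=C(COc1ccc2c(=O)ccoc2c1)Nc1cccc(NS(=O)(=O)c2ccc(OC(F)(F)F)cc2)c1` differs from compound 3 by trifluoromethoxy in place of trifluoromethyl on an aromatic carbon. Among the measured compounds shown here, the one step that bears on it, an at least 12-fold higher number from compound 2 to compound 3 (1.09 log units; beyond the scatter), shows that the trifluoromethyl group sits at the weak end of the series, and trifluoromethoxy is a closer relative of trifluoromethyl than of dimethylamino. The estimated step, a step that the limit leaves unreadable from compound 3 to compound 4, is therefore expected to stay within the scatter or to reach a higher number. In this assay compound 4 is estimated at 15000 nM, with a range from 4000 nM to 60000 nM, most likely reported again as a limit.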

Compound 4, half-maximal inhibitory concentration: 6440 nM
Beside the measured number, compound 4's estimate is 2.3-fold (0.37 log units) above it; low and high end bracket the measured number.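

Among these compounds, with trifluoromethoxy on the aromatic carbon para to a large group, compound 4 gives a numerical reading in this assay, which makes it the first compound without dimethylamino to do so. As far as these compounds go, the limits of compound 1 and compound 3 mean that the new value can be read only as an at least 1.5-fold lower number from compound 3 to compound 4 (0.19 log units; that floor lies within the scatter) and as an at least 1.5-fold lower number from compound 1 to compound 4 (0.19 log units; that floor lies within the scatter), so the true size of either step stays unknown: the limit of > 10000 nM in this assay, at which 2 of the 4 values shown sit. The step from dimethylamino now has a measured size at both ends, an 8.0-fold higher number from compound 2 to compound 4 (0.90 log units; beyond the scatter), which turns the open-ended comparison of compound 2 with compound 3 into a real number for a close relative of compound 3.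

The compounds shown leave open whether an amine other than dimethylamino, such as a primary amino group or a morpholine, or a methoxy group on the same aromatic carbon would read nearer to compound 2 or nearer to compound 4. They also leave open how a longer chain on the nitrogen, such as diethylamino, would read in this assay.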